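The source may report more compounds than this note shows. Statements on the series, on what has been measured and on what is new or still open speak of the compounds shown alone.

Measured so far:
- compound 1, `N=C(N)NCCC[C@H](NC(=O)CN(c1ncnc2c1ncn2C1CCCCO1)C1CC1)C(=O)OCc1ccccc1`, 38.2%
- compound 2, `C[C@H](NC(=O)CN(c1nc(Cl)nc2[nH]cnc12)C1CC1)C(=O)O`, 28.4%
- compound 3, `NCCCC[C@H](NC(=O)CN(c1nc(Cl)nc2[nH]cnc12)C1CC1)C(=O)OCc1ccccc1`, 16.8%

In a functional assay on the whole organism (Tail, strain ICR) with Mus musculus as the target, in the tail flick test, with a stated time of 120 min, at a dose of 25 umol/kg by the oral route (a lower number here means a weaker effect, a higher number a stronger effect of the compound at the dose given), compound 1 gives the highest of the three numbers. Compound 2 comes nearest, and the gap between the two lies within the usual scatter of such measurements, so the two cannot be ranked against each other. Compound 3, with 16.8%, sits beyond the scatter below compound 1.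

Compound 4, `CC(C)[C@H](NC(=O)CN(c1ncnc2c1ncn2C1CCCCO1)C1CC1)C(=O)OCc1ccccc1`, differs from compound 1 in one place: a group of 3 heavy atoms (3 carbon; no ring) in place of a group of 7 heavy atoms (4 carbon, 3 nitrogen; no ring), on a saturated chain carbon bound to an amide-type nitrogen and a carbonyl carbon. Among the compounds with values here, no two measured compounds differ in exactly this way, so the size of this step is not known from the data. The group that leaves carries three hydrogen-bond donors and one acceptor; the isopropyl that enters carries none. The expectation for this assay is a drop in activity, likely somewhat beyond the scatter, with the step from compound 1 to compound 4 estimated at a number 12.2 percentage points lower from compound 1 to compound 4 (beyond the scatter). Compound 4 is therefore expected to give about 26%, within a range from 10% to 42%.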

Compound 4, a percentage reported as activity, at one dose (the size of the read-out at that dose, not a potency): 25.8%
The estimate for compound 4 lay 0.2 percentage points above the measured number; the range from low to high includes it.
By their numbers in this assay, from the lowest: compounds 3, 4, 2 and 1 (each within the scatter of the next, the first and the last beyond it).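

Within the data shown here, compound 1 and compound 4 are the first pair here that differ in one place only, so the group on the saturated chain carbon bound to an amide-type nitrogen and a carbonyl carbon can now be judged on its own in this assay. Putting isopropyl there gives a number 12.4 percentage points lower from compound 1 to compound 4 (beyond the scatter), a modest step, which shows that the read-out depends on this group, although compound 4 still gives 25.8%. No measurement shown explains the drop.

Isopropyl differs from the group it replaces in both size and hydrogen-bond donors, so this single step cannot separate the two. From the compounds shown here alone, it remains open how a plain butyl chain or an amine at the end of a longer chain would compare at this place on the core of compound 1.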